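A few compounds are considered here, and "the series" means these few. Any claim that something is new, unique, unknown or untested is made for them only; others in the source may bear on it.

Compound 3 `Cc1cc(F)ccc1N(C)C(=O)c1ccc(-c2ccc(O)cc2)o1` gives 7.6 nM in an assay on T47D cells for inhibition of 17-beta-hydroxysteroid dehydrogenase type 1 (Homo sapiens), read by HPLC, with a stated time of 24 h (a lower number here means a stronger inhibitor, a higher number a weaker inhibitor), and stands lowest of the three numbers recorded there. Its nearest neighbour is compound 1 `Cc1ccccc1N(C)C(=O)c1ccc(-c2ccc(O)cc2)o1`, which gives 21 nM in this assay, and its furthest is compound 2 `Cc1cccc(F)c1N(C)C(=O)c1ccc(-c2ccc(O)cc2)o1`, which gives 120 nM in this assay; the step was a 2.8-fold lower number from compound 1 to compound 3 (0.44 log units; beyond the scatter), whereas the step was a 5.7-fold higher number from compound 1 to compound 2 (0.76 log units; beyond the scatter), so that the step was a 16-fold lower number from compound 2 to compound 3 (1.20 log units; beyond the scatter).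

Compound 4 `Cc1cccnc1N(C)C(=O)c1ccc(-c2ccc(O)cc2)o1` differs from compound 3 by 3-methylpyridin-2-yl in place of 4-fluoro-2-methylphenyl on an amide-type nitrogen. Among the measured compounds shown here, none of the measured steps covers this kind of exchange: the three steps concern only a fluoro added to the ring on the amide-type nitrogen, or the two fluoro positions against each other. What bears on it is that compound 4 gives up the fluoro whose introduction yielded the step of a 2.8-fold lower number from compound 1 to compound 3 (0.44 log units; beyond the scatter), so the number is expected to move back toward that of compound 1, with the pyridine nitrogen an unknown. The step from compound 3 to compound 4 is therefore expected to be a 5.3-fold higher number from compound 3 to compound 4 (0.72 log units; beyond the scatter). Compound 4 is estimated at 40 nM, within a range of 12 nM to 130 nM, in this assay.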

Compound 4, half-maximal inhibitory concentration: 1100 nM
For compound 4 the middle estimate is 28-fold (1.44 log units) below the measured one, and the stated range ends below it.
By their numbers in this assay, from the lowest: compound 3; then compound 1; then compound 2; then compound 4.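

In this assay, the ring on the amide-type nitrogen proves far less tolerant of a change in the ring itself than the fluoro steps suggested: 3-methylpyridin-2-yl in place of 2-methylphenyl gives a 52-fold higher number from compound 1 to compound 4 (1.72 log units; beyond the scatter), and in place of 4-fluoro-2-methylphenyl it gives a 140-fold higher number from compound 3 to compound 4 (2.16 log units; beyond the scatter). Even against 2-fluoro-6-methylphenyl, previously the poorest group at this place, the exchange gives a 9.2-fold higher number from compound 2 to compound 4 (0.96 log units; beyond the scatter), so compound 4 now has the highest number of the four. Nothing available accounts for this loss.

The compounds shown leave open whether any other ring with a hetero atom would fare as badly at this place. They also leave open whether a fluoro, a methoxy group or an amine on the 3-methylpyridin-2-yl ring would recover any of the loss.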